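The source may hold more compounds than are shown below. What is called first, only, known or untested is meant among the compounds shown, and "the series" means these compounds.

Measured compounds in an assay on microsomes for inhibition of acyl-CoA:cholesterol acyltransferase (Oryctolagus cuniculus); on this read-out higher numbers stand for weaker inhibition and lower numbers for stronger inhibition:
- compound 1 `Cc1ccccc1C1(CNC(=O)Nc2c(C(C)C)cccc2C(C)C)CCCC1`: 17 nM
- compound 2 `CC(C)c1cccc(C(C)C)c1NC(=O)NCC1(c2ccc(CC(C)(C)C)cc2)CCCC1`: 159 nM
- compound 3 `COc1cccc(C2(CNC(=O)Nc3c(C(C)C)cccc3C(C)C)CCCC2)c1`: 13 nM

All three share the same core and differ only in the aryl group on the saturated ring carbon. Compound 3 and compound 1 stand within the scatter of each other a 1.3-fold lower number from compound 1 to compound 3 (0.12 log units; within the scatter). Compound 2 stands well apart from both: a 9.4-fold higher number from compound 1 to compound 2 (0.97 log units; beyond the scatter) and a 12-fold lower number from compound 2 to compound 3 (1.09 log units; beyond the scatter), so the 4-neopentylphenyl is the one variant that clearly costs in this assay.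

Compound 4 `CC(C)c1cccc(C(C)C)c1NC(=O)NCC1(c2cccc([N+](=O)[O-])c2)CCCC1` keeps the 3-substituted phenyl of compound 3 and changes only the substituent: nitro in place of methoxy on an aromatic carbon. For the measured compounds named here, no measured step tests methoxy against nitro at this position. What bears on it is indirect: a 1.3-fold lower number from compound 1 to compound 3 (0.12 log units; within the scatter) shows that a small group on this ring, whether 2-methyl or 3-methoxy, leaves the number essentially unchanged, while the large shift a 9.4-fold higher number from compound 1 to compound 2 (0.97 log units; beyond the scatter) goes with the bulky neopentyl group and not with a small one. A nitro is of comparable size to the methoxy, so no step beyond the scatter is expected, with at most a slight rise.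

Compound 4 is therefore estimated at 20 nM, range 8 nM to 60 nM, an expected step of a 1.5-fold higher number from compound 3 to compound 4 (0.19 log units; within the scatter) from compound 3.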

Compound 4, half-maximal inhibitory concentration: 51 nM
Compound 4: the middle estimate sits 2.6-fold (0.41 log units) below what was measured; the range from low to high includes it.
By their numbers in this assay, from the lowest: compounds 3 and 1 (each within the scatter of the next); then compound 4; then compound 2.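

In this assay the aryl group on the saturated ring carbon proves sensitive to more than the bulky neopentyl: nitro in place of methoxy gives a 3.9-fold higher number from compound 3 to compound 4 (0.59 log units; beyond the scatter) and so moves the number beyond the scatter, with neither group carrying a ring or a net charge. The 3-nitrophenyl group also separates from the 2-methylphenyl group, with a 3.0-fold higher number from compound 1 to compound 4 (0.48 log units; beyond the scatter) showing that the earlier near-equality of compound 1 and compound 3 does not extend to every small substituent, while a 3.1-fold lower number from compound 2 to compound 4 (0.49 log units; beyond the scatter) leaves the 4-neopentylphenyl group still the costliest of the four variants. Nothing measured here accounts for the rise from methoxy to nitro.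

Open, going by these compounds, is whether the rise belongs to nitro alone or would also appear with a nitrile, an amine or a carboxylic acid at the same place, meta to the large group. The compounds shown also carry no single substituent on two different carbons of this aromatic ring, so the contribution of placement cannot be separated from that of the group itself.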